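Triazole and isoxazole ethers of a shared core

A few compounds are considered here, and "the series" means these few. Any claim that something is new, unique, unknown or untested is made for them only; others in the source may bear on it.

compound 1 `CCOC(=O)C1=Cc2ccccc2OC1(OCc1cc(-c2ccc(F)cc2F)no1)C(F)(F)F` — > 150000 nM
compound 2 `CCOC(=O)C1=Cc2ccccc2OC1(OCc1cn(-c2cccc(OC)c2)nn1)C(F)(F)F` — > 150000 nM

In a functional assay on DU-145 cells (Homo sapiens) for inhibition, read by MTT assay, with a stated time of 24 h (a lower number here means a stronger inhibitor, a higher number a weaker inhibitor), compound 1 gives only a limit of the assay, > 150000 nM. Compound 2 likewise gives only a limit, > 150000 nM. Compound 2 thus stands at the limit of > 150000 nM in this assay, at which 2 of the 2 values shown sit, where every value shown sits. Compound 3 `CCOC(=O)C1=Cc2ccccc2OC1(OCc1cn(CC(=O)Nc2ccc(OC)cc2)nn1)C(F)(F)F` carries ((4-methoxyphenyl)carbamoyl)methyl in place of 3-methoxyphenyl on an aromatic nitrogen, ((4-methoxyphenyl)carbamoyl)methyl in place of 3-methoxyphenyl on an aromatic nitrogen. No step between measured compounds is known; with both shown values at the limit, no step beyond the scatter is expected, and a step that the limit leaves unreadable from compound 2 to compound 3 is the expected step. Compound 3 is estimated at 200000 nM, range 60000 nM to 600000 nM, most likely again only a limit.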

Compound 3, half-maximal inhibitory concentration: 32700 nM
For compound 3 the middle estimate is 6.1-fold (0.79 log units) above the measured one; measured number outside the range, below it.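

In this assay, going by these compounds alone, the aromatic nitrogen proves to be a position where a change can move the read-out: ((4-methoxyphenyl)carbamoyl)methyl in place of 3-methoxyphenyl gives an at least 4.5-fold lower number from compound 2 to compound 3 (0.66 log units; beyond the scatter), and compound 3 is the first with a number rather than a limit. The full size of this step cannot be read, since compound 2 gives only a limit: the limit of > 150000 nM in this assay, at which 2 of the 3 values shown sit.

The amide link and the shift of the methoxy group arrive together, so the compounds shown do not separate them. As far as these compounds go, how a plain 4-methoxyphenyl or a carboxylic acid on the methyl link would read also stays open.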